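A few compounds are considered here, and "the series" means these few. Any claim that something is new, unique, unknown or untested is made for them only; others in the source may bear on it.

Compound 1 `O=C(Nc1ccc(C(F)(F)F)cc1)c1cc(Cl)ccc1O` gives 1180 nM in a toxicity assay on Vero C1008 cells (Chlorocebus sabaeus) for cytotoxicity, read by MTT assay, with a stated time of 48 h; on this read-out higher numbers stand for lower toxicity in this test and lower numbers for higher toxicity in this test. Compound 2 `O=C(Nc1cccc(C(F)(F)F)c1)c1cc(Cl)ccc1O` gives 5950 nM in this assay. The difference between the two cores is not broken down here. Compound 3 `O=C(Nc1cccc(O)c1)c1cc(Cl)ccc1O` reaches only a limit of this assay, > 100000 nM, as in the limit of > 100000 nM in this assay, at which 1 of the 3 values shown sits. The change from compound 2 to compound 3 is hydroxy in place of trifluoromethyl on an aromatic carbon, and it brings an at least 16-fold higher number from compound 2 to compound 3 (1.22 log units; beyond the scatter). Compound 4 `O=C(Nc1ccc(O)cc1)c1cc(Cl)ccc1O` is not yet measured in this assay; it differs from compound 1 by hydroxy in place of trifluoromethyl on an aromatic carbon, the same kind of change, though here para to a large group rather than meta to it. Compound 4 is expected to show a 25-fold higher number from compound 1 to compound 4 (1.41 log units; beyond the scatter), resting on the step seen from compound 2 to compound 3, an at least 16-fold higher number from compound 2 to compound 3 (1.22 log units; beyond the scatter), so that compound 4 is estimated at 30000 nM, from 7000 nM to 100000 nM.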

Compound 4, half-maximal cytotoxic concentration: > 100000 nM
Compound 4 ended at the assay's limit; the forecaster's own chance of this, stated with the estimate: 35%; middle value at least 3.3-fold (0.52 log units) away from the limit.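

In this assay, hydroxy in place of trifluoromethyl on an aromatic carbon again raises the number, with an at least 84-fold higher number from compound 1 to compound 4 (1.92 log units; beyond the scatter), so the change goes the same way on both cores shown. Compound 3 and compound 4 both stand at a limit of the assay rather than at a number: the limit of > 100000 nM in this assay, at which 2 of the 4 values shown sit. The true size of each step therefore stays unknown, and the two steps cannot be ranked: the same change on two cores in this assay, an at least 16-fold higher number (1.22 log units; beyond the scatter) from compound 2 to compound 3 and an at least 84-fold higher number (1.92 log units; beyond the scatter) from compound 1 to compound 4; the limit leaves it open whether they differ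

The compounds shown leave open whether an amine or a carboxylic acid in place of trifluoromethyl would raise the number as far as hydroxy does. They also leave open how a methoxy group would compare with both.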